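From Pyridin-3-yl to Thiophen-3-yl on a Shared Core

A few compounds are considered here, and "the series" means these few. Any claim that something is new, unique, unknown or untested is made for them only; others in the source may bear on it.

Measured in a functional assay on SK-BR-3 cells (Homo sapiens) for inhibition, read by CellTiter-Glo, with a stated time of 72 h; on this read-out lower numbers stand for stronger inhibition and higher numbers for weaker inhibition:

- Compound 1 `CC(C)c1nn(-c2ccc(C(N)=O)c(N[C@H]3CC[C@H](O)CC3)c2)c2nccc(-c3ccccc3)c12`: > 10000 nM (a limit)
- Compound 2 `CC(C)c1nn(-c2ccc(C(N)=O)c(N[C@H]3CC[C@H](O)CC3)c2)c2nccc(-c3ccc4ccccc4c3)c12`: > 10000 nM (a limit)
- Compound 3 `CC(C)c1nn(-c2ccc(C(N)=O)c(N[C@H]3CC[C@H](O)CC3)c2)c2nccc(-c3cccnc3)c12`: 464 nM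

Compound 3 is the only one of the three with a number, 464 nM. The other two values are limits, as the limit of > 10000 nM in this assay, at which 2 of the 3 values shown sit, records.

Compound 4 `CC(C)c1nn(-c2ccc(C(N)=O)c(N[C@H]3CC[C@H](O)CC3)c2)c2nccc(-c3ccsc3)c12` has not yet been measured in this assay. It carries thiophen-3-yl in place of pyridin-3-yl on an aromatic carbon, and the change is thiophen-3-yl in place of pyridin-3-yl on an aromatic carbon.

Among the compounds with values here, two measured steps bear on this change, both involving the same aromatic carbon. Pyridin-3-yl replacing phenyl gave an at least 21-fold lower number from compound 1 to compound 3 (1.33 log units; beyond the scatter). Pyridin-3-yl replacing naphthalen-2-yl gave an at least 21-fold lower number from compound 2 to compound 3 (1.33 log units; beyond the scatter). Both steps are large and both end at pyridin-3-yl, so removing that group points towards a higher number. Within the data shown here, no measured compound carries thiophen-3-yl, however, so the size of the step remains uncertain, and a smaller loss than those two steps suggest is possible.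

The expected result is a 5.4-fold higher number from compound 3 to compound 4 (0.73 log units; beyond the scatter), and this is an estimate. Compound 4 is expected at 2500 nM, with an estimated range of 500 nM to 10000 nM.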

Compound 4, half-maximal inhibitory concentration: > 10000 nM
Compound 4 ended at the assay's limit; the forecaster's own chance of this, stated with the estimate: 30%; at least 4.0-fold (0.60 log units) between middle value and limit.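

In this assay, thiophen-3-yl in place of pyridin-3-yl on this aromatic carbon gives an at least 21-fold higher number from compound 3 to compound 4 (1.33 log units; beyond the scatter). The earlier compounds shown here showed this loss only against phenyl and naphthalen-2-yl, whereas thiophen-3-yl has the same count of hetero atoms and hydrogen-bond acceptors as pyridin-3-yl, so those counts alone do not separate compound 3 from compound 4. Of the four groups shown at this position, only pyridin-3-yl gives a number, and the other three compounds end at the same value: the limit of > 10000 nM in this assay, at which 3 of the 4 values shown sit.

On these data alone, it remains open whether the six-membered ring with its nitrogen is what sets compound 3 apart, a question that groups such as pyridin-4-yl, pyridin-2-yl or pyrimidin-5-yl on the same carbon would address. As far as these compounds go, the steps among compound 1, compound 2 and compound 4 cannot be read, so the order of these three compounds stays unknown.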